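Aryl swap on the sulfonyl sulfur: compound 3 to compound 4

The compounds below may be only part of what the source reports. "The series", "measured", "known", "first", "only" and "open" are said of these compounds alone.

The series is read in a functional assay on HEK293 cells (Homo sapiens) for cytotoxicity; on this read-out lower numbers stand for higher toxicity in this test and higher numbers for lower toxicity in this test. Compound 3 `COc1ccc([C@H]2CC(=O)N(c3cccc(NS(=O)(=O)c4ccccc4Cl)c3)C2)cc1OC1CCCC1` carries a (2-chlorophenyl)sulfonyl on a nitrogen on an aromatic ring. In this assay compound 3 gives > 10000 nM, which is a limit of the assay and not a number. Compound 1 `COc1ccc([C@H]2CC(=O)N(c3cccc(NCc4ccoc4)c3)C2)cc1OC1CCCC1`, with (furan-3-yl)methyl in that place, gives > 10000 nM, likewise a limit. Compound 2 `COc1ccc(OC)c(S(=O)(=O)Nc2cccc(N3C[C@@H](c4ccc(OC)c(OC5CCCC5)c4)CC3=O)c2)c1`, with 2,5-dimethoxyphenyl on the sulfonyl sulfur, gives 7590 nM in this assay. The step that the two limits leave unreadable from compound 1 to compound 3 stays unreadable; its two ends are both limits. The step of an at least 1.3-fold higher number from compound 2 to compound 3 (0.11 log units; that floor lies within the scatter) is the only one with a size, and that floor sits within the scatter. Compound 3 therefore stands at the limit of > 10000 nM in this assay, at which 2 of the 3 values shown sit, with no number of its own below it.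

Compound 4 `COc1ccc([C@H]2CC(=O)N(c3cccc(NS(=O)(=O)c4cccc(C)c4)c3)C2)cc1OC1CCCC1` differs from compound 3 only at the sulfonyl sulfur: 3-methylphenyl in place of 2-chlorophenyl on a sulfonyl sulfur. Among the measured compounds shown here, the one measured comparison that bears on this place is the aryl exchange an at least 1.3-fold higher number from compound 2 to compound 3 (0.11 log units; that floor lies within the scatter), which gave no movement beyond the scatter. No step beyond the scatter is expected here either. Compound 4 is expected to give 10000 nM in this assay, with a range from 5000 nM to 25000 nM. The step of a number no higher from compound 3 to compound 4 (the limit leaves the size open) is thus expected to stay within the scatter, and a limit rather than a number is the likelier report.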

Compound 4, half-maximal cytotoxic concentration: > 10000 nM
Compound 4 ended at the assay's limit (the forecaster's own chance of this, stated with the estimate: 65%); the middle value lies on the limit itself.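

Compound 4 gives a second aryl group on the sulfonyl sulfur, 3-methylphenyl, that reaches the limit of this assay, so the reading at this place no longer rests on 2-chlorophenyl alone: the limit of > 10000 nM in this assay, at which 3 of the 4 values shown sit.

Among the compounds shown here, the only step involving compound 4 that has a size is an at least 1.3-fold higher number from compound 2 to compound 4 (0.11 log units; that floor lies within the scatter), so this floor does not separate 3-methylphenyl from 2,5-dimethoxyphenyl any more than an at least 1.3-fold higher number from compound 2 to compound 3 (0.11 log units; that floor lies within the scatter) separates 2-chlorophenyl from it. The steps to compound 4 from compound 1 and from compound 3 cannot be read, as both ends of each are limits.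

Going by these compounds, how far compound 1, compound 3 and compound 4 lie beyond the limit stays open, and so does any ranking among the aryl groups on the sulfonyl sulfur in this assay. Also open, on these data alone, is whether a phenyl carrying an amine or a carboxylic acid, or a longer alkyl chain in place of the aryl group on the sulfonyl sulfur, would give a number within the range of the assay.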